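Benzylsulfanyl in Place of Ethylsulfanyl: Expecting Compound 4

This account rests on a few compounds, and the source may have more. Where it says the series, first, only, none or still open, it means among the compounds named here.

Of the compounds shown here, three sharing one core have been tested in a functional assay on the whole organism (strain NMRI) with Mus musculus as the target, with a stated time of 60 min, at a dose of 10 mg/kg by the intraperitoneal route; a lower number here means a weaker effect, a higher number a stronger effect of the compound at the dose given. Compound 1 `CCSc1nnc(Cc2ccc(Cl)cc2Oc2ccccc2Cl)[nH]1` gives 140%. Compound 2 `Clc1ccc(Cc2nnc(SCc3ccccc3)[nH]2)c(Oc2ccccc2Cl)c1` gives 122%. Compound 3 `CCSc1nnc(Cc2ccc(Cl)cc2Oc2ccccc2F)[nH]1` gives 144%, the largest of the three numbers, yet its gap to compound 1 lies within the usual scatter and only its gap to compound 2 lies beyond it.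

Compound 4 `Fc1ccccc1Oc1cc(Cl)ccc1Cc1nnc(SCc2ccccc2)[nH]1` has not yet been measured. It differs from compound 3 in a single place: phenyl in place of methyl on a saturated chain carbon bound to a sulfur.

Among the compounds with values here, one measured step bears directly on this change. The same exchange, ethyl to benzyl, separates compound 1 from compound 2, where the result was a number 18 percentage points lower from compound 1 to compound 2 (beyond the scatter). The move from chloro to fluoro, a number 4 percentage points higher from compound 1 to compound 3 (within the scatter), stayed within the scatter and does not alter that picture. A step of similar size and direction is therefore expected for compound 4 in this assay, namely a number 18 percentage points lower from compound 3 to compound 4 (beyond the scatter), and compound 4 is estimated to give 126%, most likely between 110% and 142%.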

Compound 4, a percentage reported as activity, at one dose (the size of the read-out at that dose, not a potency): 169%
For compound 4 the middle estimate is 43 percentage points below the measured one; measured number above the stated range.
By their numbers in this assay, from the lowest: compound 2; then compounds 1 and 3 (each within the scatter of the next); then compound 4.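

In this assay, the exchange of ethylsulfanyl for benzylsulfanyl has no fixed effect of its own, since on the fluoro compound it gives a number 25 percentage points higher from compound 3 to compound 4 (beyond the scatter), and its direction depends on the halogen elsewhere in the molecule: the same change on two cores in this assay, a number 18 percentage points lower (beyond the scatter) from compound 1 to compound 2 and a number 25 percentage points higher (beyond the scatter) from compound 3 to compound 4, 43 percentage points apart, beyond the scatter of two such steps

The exchange of chloro for fluoro, which looked negligible with ethylsulfanyl in place, becomes a clear gain with benzylsulfanyl, giving a number 47 percentage points higher from compound 2 to compound 4 (beyond the scatter): the same change on two cores in this assay, a number 4 percentage points higher (within the scatter) from compound 1 to compound 3 and a number 47 percentage points higher (beyond the scatter) from compound 2 to compound 4, 43 percentage points apart, beyond the scatter of two such steps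

The two places therefore do not add up independently in these four compounds, and a step measured on one core cannot simply be carried over to another.

Going by these compounds, it remains open whether this interplay extends to other groups on the sulfur, such as a longer chain like propyl or a cyclohexylmethyl group, or to other halogens such as bromo. These four compounds also give no reason why the two changes depend on each other.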